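The source may report more compounds than this note shows. Statements on the series, on what has been measured and on what is new or still open speak of the compounds shown alone.

Measured in a functional assay on MCF cells (Homo sapiens) for antiproliferative activity, with a stated time of 72 h; a lower number here means a stronger inhibitor, a higher number a weaker inhibitor (each value a limit, not a number):
compound 1 `OC[C@H]1O[C@@H](n2cnc3c(NCc4ccccc4Br)ncnc32)[C@H](O)[C@@H]1O` gives > 166000 nM as a limit
compound 2 `Cc1cccc(CNc2ncnc3c2ncn3[C@@H]2O[C@H](CO)[C@@H](O)[C@H]2O)c1` gives > 166000 nM as a limit
compound 3 `OC[C@H]1O[C@@H](n2cnc3c(NCc4cc(O)cc(O)c4)ncnc32)[C@H](O)[C@@H]1O` gives > 166000 nM as a limit

Compound 3 therefore has no numerical value of its own, and its place in the series cannot be ranked against compound 1 or compound 2. Within the data shown here, the only evidence on the series so far is the limit of > 166000 nM in this assay, at which 3 of the 3 values shown sit, and no compound has yet given a number.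

The next step leads to compound 4 `OC[C@H]1O[C@@H](n2cnc3c(NCc4ccccc4OC(F)F)ncnc32)[C@H](O)[C@@H]1O` and alters only the group on the saturated chain carbon, leaving the shared core as it is: 2-(difluoromethoxy)phenyl in place of 3,5-dihydroxyphenyl on a saturated chain carbon bound to a nitrogen on an aromatic ring is the change.

Among the measured compounds shown here, three measured steps bear on it: a step that the two limits leave unreadable from compound 1 to compound 2 and a step that the two limits leave unreadable from compound 1 to compound 3 and also a step that the two limits leave unreadable from compound 2 to compound 3 are the ones available. None of them has a readable size, so none offers a direction for the new group. With 2-bromophenyl, 3-methylphenyl and 3,5-dihydroxyphenyl all ending at the same limit, the working expectation is that 2-(difluoromethoxy)phenyl ends there too.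

No step beyond the scatter is expected in this assay in either direction, and the estimated step is a step that the limit leaves unreadable from compound 3 to compound 4 as a working figure only.

For compound 4 the estimated value is 170000 nM with an expected range from 60000 nM to 300000 nM and a report of a limit alone is the likeliest result.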

Compound 4, half-maximal inhibitory concentration: > 166000 nM
Compound 4 was reported as a limit (the forecaster's own chance of this, stated with the estimate: 85%); the middle value does not contradict the limit.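

In this assay compound 4 gives > 166000 nM, a limit and not a number. The steps to compound 4 from compound 1, compound 2 and compound 3 cannot be read: the limit of > 166000 nM in this assay, at which 4 of the 4 values shown sit. The compounds shown leave open whether any group on the saturated chain carbon gives a numerical value in this assay.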